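A few compounds are considered here, and "the series" means these few. Any claim that something is new, unique, unknown or untested is made for them only; others in the source may bear on it.

Of the compounds shown here, two have numbers so far in a physicochemical assay for metabolic stability, read by HPLC; on this read-out lower numbers stand for a shorter-lived compound and higher numbers for a longer-lived compound. Compound 1 `Cc1cn([C@H]2C[C@H](N=[N+]=[N-])[C@@H](COP(=O)(O)Oc3ccncc3)O2)c(=O)[nH]c1=O` gives 8.07 h, and compound 2 `Nc1ncnc2c1ncn2[C@H]1CC[C@@H](COP(=O)(O)Oc2ccccc2)O1` gives 36.1 h. Compound 2 therefore stands higher of the two, and the gap between them lies beyond the scatter. The two compounds differ in more than one place, so their values show only that gap and isolate no single change.

The next compound is compound 3 `Nc1ncnc2c1ncn2[C@H]1CC[C@@H](COP(=O)(O)Oc2cccnc2)O1`, with pyridin-3-yl in place of phenyl on an oxygen whose other neighbours are: phosphorus (pyridin-3-yl in place of phenyl on an oxygen). The shared core of compound 2 stays untouched. For the measured compounds named here, no measured pair tests this change alone, so the expectation is weakly founded. A fall in this assay beyond the scatter is expected, resting only on compound 1, which also has an aromatic ring with a hetero atom on such an oxygen and gives 8.07 h. The expected change is a 2.6-fold lower number from compound 2 to compound 3 (0.41 log units; beyond the scatter). For compound 3 the estimated half-life is 14 h, with an expected range of 5 h to 35 h.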

Compound 3, half-life: 64.2 h
The estimate for compound 3 lay 4.6-fold (0.66 log units) below the measured number; the whole stated range lies below it.
By their numbers in this assay, from the lowest: compound 1; then compounds 2 and 3 (each within the scatter of the next).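

In this assay, for the compounds shown here, pyridin-3-yl in place of phenyl on an oxygen whose other neighbours are: phosphorus gives a 1.8-fold higher number from compound 2 to compound 3 (0.25 log units; within the scatter), the first step that isolates a single change. With the shared core held fixed, this exchange of rings, which keeps the heavy-atom count and adds one hydrogen-bond acceptor, leaves compound 2 and compound 3 indistinguishable in half-life, so at this position the ring nitrogen of pyridin-3-yl produces no change that can be resolved from repeat-measurement noise. Nothing at hand explains this result or bears on how the ring nitrogen is tolerated here.

A single exchange on one core cannot show whether this position is insensitive in general, and a phenyl ring bearing a carboxylic acid or an amine on the same oxygen would test that more severely than a change of one ring atom. Going by these compounds, whether pyridin-3-yl in place of phenyl would give a similar step on the core of compound 1 also remains open, and the gap between that compound and the other two cannot yet be assigned to any one place.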